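The source may hold more compounds than are shown below. What is called first, only, known or untested is meant among the compounds shown, and "the series" means these compounds.

Measured compounds in a functional assay on CCRF-CEM cells (Homo sapiens) for inhibition, read by cell counting, with a stated time of 3 days; on this read-out lower numbers stand for stronger inhibition and higher numbers for weaker inhibition:

compound 1 `Nc1cccc(-c2cn3nc(-c4cccs4)sc3n2)c1`: > 250000 nM — a limit of the assay, not a number
compound 2 `Nc1cccc(-c2cn3c(-c4ccccc4)csc3n2)c1`: 29000 nM
compound 3 `C=C(Br)C(=O)Nc1cccc(-c2cn3nc(-c4cccs4)sc3n2)c1`: 410 nM

Compound 1 stands at the limit of this assay, with no numerical value (the limit of > 250000 nM in this assay, at which 1 of the 3 values shown sits). Within the data shown here, compound 3 carries the (1-bromoethenyl)carbonyl group on the nitrogen on an aromatic ring and shows the only step that has been worked out, an at least 600-fold lower number from compound 1 to compound 3 (2.78 log units; beyond the scatter). That step concerns the nitrogen substituent and leaves the rest of the core of compound 1 untouched.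

Compound 4 `Nc1cccc(-c2cn3nc(-c4ccc(F)cc4)sc3n2)c1` is the next compound to be measured. 4-fluorophenyl in place of thiophen-2-yl on an aromatic carbon The change sits on the aromatic carbon of the core and keeps the nitrogen on the aromatic ring bare, so the measured step from compound 1 to compound 3 does not bear on it directly. Among the measured compounds shown here, compound 2, which has a different core and a phenyl group, gives 29000 nM in this assay; it shares no single-point change with compound 1 or compound 4, so it offers no step to lean on.

For the measured compounds named here, with only a limit as the starting point and no measured step at the varied position, no movement beyond the scatter is expected; compound 4 is expected to show an at least 1.2-fold lower number from compound 1 to compound 4 (0.09 log units; that floor lies within the scatter). Compound 4 is therefore estimated at 200000 nM, with a range from 50000 nM to 600000 nM, and a good chance that this assay again reports only a limit.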

Compound 4, half-maximal inhibitory concentration: >= 250000 nM
Compound 4 gave a limit, no number; the forecaster's own chance of this, stated with the estimate: 60%; middle value at least 1.2-fold (0.09 log units) away from the limit.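

Compound 1 and compound 4 both stand at a limit of this assay, not at a number, and the step between them cannot be read. The compounds shown leave open how 4-fluorophenyl and thiophen-2-yl compare on the shared core, including when the nitrogen carries the (1-bromoethenyl)carbonyl group.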